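Cytotoxicity notes on a quinoline urea series

The compounds below may be only part of what the source reports. "The series", "measured", "known", "first", "only" and "open" are said of these compounds alone.

For the measured compounds named here, compound 1 `COc1cc(NC(C)CCCNC(=O)NCCO)c2ncccc2c1` gives "not determined" (no result reported) in an ADME assay on L6 cells (Rattus norvegicus) for cytotoxicity, read by resazurin assay, with a stated time of 70 h (a higher number here means a weaker inhibitor, a lower number a stronger inhibitor), and compound 2 `COc1cc(NC(C)CCCNC(=O)NCCCO)c2ncccc2c1` gives "not determined" (no result reported) in this assay, so neither carries a result; compound 3 `COc1cc(NC(C)CCCNC(=O)NNC(=O)/C=C/c2ccccc2)c2ncccc2c1` gives the only number in the set, 13900 nM in this assay, so it alone anchors the series. Going by the values given here, no step between measured compounds is available. Compound 4 `COc1cc(NC(C)CCCNC(=O)NNC(=O)Nc2cccc(C(F)(F)F)c2)c2ncccc2c1` differs from compound 3 in one place: (3-(trifluoromethyl)phenyl)amino in place of 2-phenylethenyl on a carbonyl carbon. With nothing beyond compound 3 to compare, the change from compound 3 to compound 4 is expected to move this assay by at most a small amount, if anything toward a stronger inhibitor, and the step of a 1.4-fold lower number from compound 3 to compound 4 (0.14 log units; within the scatter) is an estimate resting only on compound 3 at 13900 nM. Compound 4 is therefore expected to give about 10000 nM in this assay, with a range from 3000 nM to 35000 nM.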

Compound 4, half-maximal inhibitory concentration: 32100 nM
For compound 4 the middle estimate is 3.2-fold (0.51 log units) below the measured one; low and high end bracket the measured number.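

For the compounds shown here, at the carbonyl carbon, (3-(trifluoromethyl)phenyl)amino in place of 2-phenylethenyl gives a 2.3-fold higher number from compound 3 to compound 4 (0.36 log units; beyond the scatter), a modest move toward a weaker inhibitor and the first evidence that this position affects the read-out in this assay. The change removes a double bond outside aromatic rings and adds a hydrogen-bond donor and trifluoromethyl together, so this single pair cannot separate their contributions.

Still open, going by these compounds, is how a plain phenylamino group or a carboxylic acid on the aromatic ring would read in this assay. The reason for the shift also stays open, as nothing measured here bears on it.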